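The compounds below may be only part of what the source reports. "The series", "measured", "known", "first", "only" and "open" are said of these compounds alone.

Compound 1 `COc1cc(/C=C/C(=O)c2cccc(N)c2)ccc1O`: 12.3 ug/mL
Compound 2 `COc1cc(/C=C/C(=O)c2cccc(NC(=O)c3ccc(Cl)c(Cl)c3)c2)ccc1O`: 25.3 ug/mL

Among the measured compounds shown here, in a functional assay on SiHa cells (Homo sapiens) for inhibition (a higher number here means a weaker inhibitor, a lower number a stronger inhibitor), compound 2 has the higher of the two numbers measured so far, at 25.3 ug/mL. Compound 3 `COc1cc(/C=C/C(=O)c2cccc(NC(=O)C(C)C)c2)ccc1O` departs from compound 2 at one place: isopropyl in place of 3,4-dichlorophenyl on a carbonyl carbon. In words, isopropyl stands in place of 3,4-dichlorophenyl on a carbonyl carbon.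

For the measured compounds named here, only one measured step bears on this change: a 2.1-fold higher number from compound 1 to compound 2 (0.31 log units; beyond the scatter). That modest step introduced the (3,4-dichlorophenyl)carbonyl group now being replaced. Going by the values given here, no compound with isopropylcarbonyl has been measured, so the guide is indirect. A modest move back towards compound 1, which gives 12.3 ug/mL, is the most reasonable expectation, although a change within the scatter would not be surprising. The expected step is a 1.4-fold lower number from compound 2 to compound 3 (0.15 log units; within the scatter), towards a lower number. For compound 3, the estimated value is 18 ug/mL, with an expected range of 9 ug/mL to 36 ug/mL.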

Compound 3, half-maximal inhibitory concentration: 5.96 ug/mL
For compound 3 the middle estimate is 3.0-fold (0.48 log units) above the measured one; the measured number lies below the stated range.
By their numbers in this assay, from the lowest: compound 3; then compound 1; then compound 2.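

In this assay, a carbonyl group on the nitrogen on the aromatic ring does not simply raise the number: with isopropylcarbonyl in place of hydrogen, the step is a 2.1-fold lower number from compound 1 to compound 3 (0.31 log units; beyond the scatter), opposite in direction to the step with (3,4-dichlorophenyl)carbonyl, a 2.1-fold higher number from compound 1 to compound 2 (0.31 log units; beyond the scatter). The result at this position therefore depends on the group on the carbonyl carbon, with isopropyl and 3,4-dichlorophenyl separated by a 4.2-fold lower number from compound 2 to compound 3 (0.63 log units; beyond the scatter). Nothing measured bears on the reason for this difference.

The compounds shown place only one alkyl group and one substituted phenyl group on the carbonyl carbon, so it remains open whether isopropyl stands for alkyl groups more widely or whether the chlorines on the phenyl ring contribute to the higher number. A methyl group, a longer chain such as n-butyl, and an unsubstituted phenyl ring would each help to separate these readings.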